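This account rests on a few compounds, and the source may have more. Where it says the series, first, only, none or still open, it means among the compounds named here.

Measured so far:
compound 1 `C=CC(=O)N1CC(NC(=O)Cn2cc(C(=O)N3CCc4ccccc4C3)c3cc(Br)ccc32)C1` gives 1.67 h in a physicochemical assay for pharmacokinetics, read by LC-MS, in phosphate buffer, at pH 7.4, in the presence of a further agent that is not named here; on this read-out higher numbers stand for a longer-lived compound and lower numbers for a shorter-lived compound
compound 2 `C=CC(=O)N1CC(NC(=O)Cn2cc(C(=O)N3CCc4c(Cl)cccc4C3)c3cc(Br)ccc32)C1` gives 1.67 h in this assay

Compound 2 stands level with compound 1 at the digits shown; the one step recorded so far, no change at the digits printed from compound 1 to compound 2 (within the scatter), lies within the scatter.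

Compound 3 `C=CC(=O)N1CC(NC(=O)Cn2cc(C(=O)N(C)Cc3ccccc3)c3cc(Br)ccc32)C1` is the next member. From compound 2 it differs by a group of 9 heavy atoms (8 carbon, 1 nitrogen; one six-membered aromatic ring of carbon only) in place of a group of 11 heavy atoms (9 carbon, 1 nitrogen, 1 chlorine; one six-membered non-aromatic ring with 1 hetero atom, one six-membered aromatic ring of carbon only), on a carbonyl carbon. The acrylamide and the rest of the shared core are untouched.

Going by the values given here, only one measured step bears on this change, and only loosely: from compound 1 to compound 2 the amide substituent was altered and this assay did not move. Among the compounds with values here, no measured step covers an opened or removed ring at this carbonyl. On that basis no step beyond the scatter is expected from compound 2 to compound 3, a 1.0-fold higher number from compound 2 to compound 3 (0.01 log units; within the scatter). Compound 3 is therefore estimated at 1.7 h in this assay, with a range from 0.9 h to 3.3 h.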

Compound 3, half-life: 1.67 h
Estimate against measurement, compound 3: 1.0-fold (0.01 log units) above; measured number inside the range.
By their numbers in this assay, from the lowest: compounds 1, 2 and 3 (each within the scatter of the next).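

In this assay, benzyl(methyl)amino in place of 1,2,3,4-tetrahydroisoquinolin-2-yl on the carbonyl carbon gives no change at the digits printed from compound 1 to compound 3 (within the scatter) and thus shows that this position tolerates an open-chain amine substituent as well as the ring. The exchange that also removes the chloro gives no change at the digits printed from compound 2 to compound 3 (within the scatter) and adds a second kind of change at this carbonyl to the chloro step, so across these three compounds no change to this amide substituent has moved the read-out beyond the scatter. No supporting data are available to account for this flat result.

From the compounds shown here alone, all three compounds retain the acrylamide and carry a six-membered aromatic ring of carbon only in the amide substituent, so it remains open whether the half-life would hold with a morpholine or a piperazine on this carbonyl carbon, or with a carboxylic acid on the aromatic ring. Going by these compounds, it is equally open whether the number depends on the acrylamide itself, as a propanamide in its place would show.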